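Swapping a Pyridinyl for Phenyl on a Shared Core

The compounds below may be only part of what the source reports. "The series", "measured", "known", "first", "only" and "open" are said of these compounds alone.

Compound 1 `Oc1cccc(-c2cc(-c3ccc(Cl)cc3)nc(-c3ccco3)c2)c1` gives 11400 nM.
Compound 2 `Oc1cccc(-c2cc(-c3ccncc3)nc(-c3ccccc3Cl)c2)c1` gives "not determined" (no result reported).
Compound 3 `Oc1cccc(-c2cc(-c3ccsc3)nc(-c3cccc(Cl)c3)c2)c1` gives 3330 nM.

All three share a core and were tested in a functional assay on DU-145 cells (Homo sapiens) for cytotoxicity, read by CCK-8 assay and cell counting, with a stated time of 2 days; on this read-out lower numbers stand for stronger inhibition and higher numbers for weaker inhibition. Compound 2 stands nowhere on these numbers: it has no result, so it cannot be placed against compound 1 or compound 3, whose values lie in the micromolar region.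

Compound 4 `Oc1cccc(-c2cc(-c3ccccc3)nc(-c3ccccc3Cl)c2)c1` differs from compound 2 in one place: phenyl in place of pyridin-4-yl on an aromatic carbon. Among the measured compounds shown here, no two measured compounds differ by a single change, so no step size can be read from the data. Without such a step, the change is expected to move this assay little, if at all, beyond the usual scatter.

Compound 4 is therefore expected to give about 5000 nM, with a range from 1500 nM to 20000 nM.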

Compound 4, half-maximal inhibitory concentration: 1480 nM
Beside the measured number, compound 4's estimate is 3.4-fold (0.53 log units) above it, outside the stated range (below it).
By their numbers in this assay, from the lowest: compound 4; then compound 3; then compound 1.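

Compound 4 gives 1480 nM but compound 2 has no number to set against it, so no step can be read between them. No evidence here bears on this result. As far as these compounds go, whether phenyl in place of pyridin-4-yl changes the value stays open.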